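Phenyl in Place of Propyl on a Carbamate Oxygen

The compounds below may be only part of what the source reports. "The series", "measured", "known", "first", "only" and "open" are said of these compounds alone.

Measured compounds:
compound 1, `C=CCOC(=O)Nc1ccc([Se]C#N)cc1`, gives 48600 nM in a functional assay on HT-29 cells (Homo sapiens) for cytotoxicity, read by MTT assay, with a stated time of 72 h; on this read-out higher numbers stand for weaker inhibition of growth and lower numbers for stronger inhibition of growth
compound 2, `CCCOC(=O)Nc1ccc([Se]C#N)cc1`, gives 51900 nM in this assay

For the measured compounds named here, compound 2 gives the larger of the two numbers so far, but its only neighbour is compound 1, and the step of a 1.1-fold higher number from compound 1 to compound 2 (0.03 log units; within the scatter) is within the scatter, so the two compounds cannot be told apart. Compound 3, `N#C[Se]c1ccc(NC(=O)Oc2ccccc2)cc1`, differs from compound 2 by phenyl in place of propyl on an oxygen next to a carbonyl group. Going by the values given here, the single measured step, a 1.1-fold higher number from compound 1 to compound 2 (0.03 log units; within the scatter), concerns a small change on the chain and was flat; no measured pair replaces the whole chain by a ring, so it bears on the new step only loosely. The expectation is therefore a step of a 1.3-fold lower number from compound 2 to compound 3 (0.11 log units; within the scatter) in this assay, which is not beyond the scatter. Compound 3 is estimated to give 40000 nM, within a range from 15000 nM to 110000 nM.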

Compound 3, concentration for total growth inhibition: 41700 nM
Compound 3: the middle estimate sits 1.0-fold (0.02 log units) below what was measured, and the stated range covers the measured number.
By their numbers in this assay, from the lowest: compounds 3, 1 and 2 (each within the scatter of the next).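

Up to now, this position had only been probed with two small open chains, so compound 3 adds something new: an aromatic ring on the oxygen next to the carbonyl group. In this assay, this larger change still gives only a small step, both against the saturated chain (a step of a 1.2-fold lower number from compound 2 to compound 3 (0.10 log units; within the scatter)) and against the allyl chain (a step of a 1.2-fold lower number from compound 1 to compound 3 (0.07 log units; within the scatter)), so propyl, allyl and phenyl cannot be told apart here. Nothing available explains why the numbers stay so close.

From the compounds shown here alone, it remains open whether any group on this oxygen can move the number beyond the scatter. A much longer chain, a benzyl group, or a chain carrying an amine or a carboxylic acid would each test this further.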